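This account rests on a few compounds, and the source may have more. Where it says the series, first, only, none or still open, it means among the compounds named here.

In an assay on microsomes from liver for inhibition of sterol O-acyltransferase 1 (Rattus norvegicus) (on this read-out lower numbers stand for stronger inhibition and higher numbers for weaker inhibition), three compounds have been measured so far:

Compound 1 `O=c1cc(-c2ccccc2)c(-c2ccccc2)nn1C1CCCCC1` gives > 300000 nM, which is a limit of the assay and not a number.
Compound 2 `CCCCCCn1nc(-c2ccccc2)c(-c2ccccc2)c(C)c1=O` gives 56000 nM.
Compound 3 `CCCCCC(=O)Nc1cc(-c2ccccc2)c(-c2ccccc2)nn1` gives > 300000 nM, again a limit of the assay rather than a number.

Compound 3 therefore stands at the limit of this assay, with no number of its own. Two of the three values shown sit at that limit (the limit of > 300000 nM in this assay, at which 2 of the 3 values shown sit), so it is the weak end of this small set, and only compound 2 has a measured number. Among the compounds with values here, no step between two measured compounds that differ in a single place is available, so the size of any single change here has not been seen directly.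

Compound 4 `CCCCCC[S+]([O-])c1cc(-c2ccccc2)c(-c2ccccc2)nn1` differs from compound 3 in one place: a group of 8 heavy atoms (6 carbon, 1 oxygen, 1 sulfur; no ring) in place of a group of 8 heavy atoms (6 carbon, 1 nitrogen, 1 oxygen; no ring), on an aromatic carbon. Within the data shown here, since no comparable step has been measured, the direction and size of the change can only be guessed. Compound 4 is expected to give about 150000 nM in this assay, within a range of 30000 nM to 600000 nM. The step from compound 3 to compound 4 is thus estimated at an at least 2.0-fold lower number from compound 3 to compound 4 (0.30 log units; that floor lies within the scatter), and it remains quite possible that compound 4 will again be reported only as a limit.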

Compound 4, half-maximal inhibitory concentration: 75000 nM
Estimate against measurement, compound 4: 2.0-fold (0.30 log units) above; the measured number falls inside the stated range.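

At this aromatic carbon next to the ring nitrogen, the six-carbon group with sulfur and oxygen in place of (pentylcarbonyl)amino gives an at least 4.0-fold lower number from compound 3 to compound 4 (0.60 log units; beyond the scatter) in this assay. Within the data shown here, this is the first step across a single place in the set, and it shows that the group on this carbon can yield a measured number, with compound 4 at 75000 nM. Compound 3 gives > 300000 nM, a limit of the assay and not a number, so the step has only a floor: the limit of > 300000 nM in this assay, at which 2 of the 4 values shown sit.

The compounds shown do not separate the loss of the hydrogen-bond donor from the change of the atom joined to the ring. As far as these compounds go, how an amine, a thioether or a longer chain on this carbon would read also remains open.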